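The compounds below may be only part of what the source reports. "The series", "measured", "known", "first", "only" and "open" are said of these compounds alone.

Three compounds share one core, an aryl ring bearing a methyl group and an imidazoline-type amine, with a second aromatic ring attached. Compound 1 `Cc1c(NC2=NCCN2)cccc1-c1ccccc1` carries no further group on that second ring; in an assay on cell membranes for binding affinity to 5-hydroxytryptamine receptor 7 (Rattus norvegicus) (a lower number here means a stronger inhibitor, a higher number a weaker inhibitor), compound 1 gives 16.2 nM. Compound 2 `COc1cccc(-c2cccc(NC3=NCCN3)c2C)c1` adds a methoxy group, and in this assay compound 2 gives 35.5 nM, a step of a 2.2-fold higher number from compound 1 to compound 2 (0.34 log units; beyond the scatter). Compound 3 `Cc1c(NC2=NCCN2)cccc1-c1cccc(C#N)c1` carries a cyano group instead, and in this assay compound 3 gives 170 nM, the highest of the three numbers, reached by a 10-fold higher number from compound 1 to compound 3 (1.02 log units; beyond the scatter) and by a 4.8-fold higher number from compound 2 to compound 3 (0.68 log units; beyond the scatter).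

Compound 4 `Cc1c(NC2=NCCN2)cccc1-c1cccc(C(C)C)c1` differs from compound 3 in one place: isopropyl in place of cyano on an aromatic carbon. Among the measured compounds shown here, two measured steps bear on this. Removing the cyano group in favour of hydrogen gave the large drop seen in a 10-fold higher number from compound 1 to compound 3 (1.02 log units; beyond the scatter) read in reverse, and swapping cyano for methoxy gave the modest drop of a 4.8-fold higher number from compound 2 to compound 3 (0.68 log units; beyond the scatter) read in reverse. Isopropyl is neither hydrogen nor methoxy, so the size is uncertain, but on this evidence compound 4 is expected to give a lower number than compound 3, a step of roughly a 4.9-fold lower number from compound 3 to compound 4 (0.69 log units; beyond the scatter). The estimate for compound 4 is therefore 35 nM, expected to fall between 10 nM and 120 nM.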

Compound 4, inhibition constant: 182 nM
The estimate for compound 4 lay 5.2-fold (0.72 log units) below the measured number; measured number above the stated range.
By their numbers in this assay, from the lowest: compound 1; then compound 2; then compounds 3 and 4 (each within the scatter of the next).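

On this aromatic carbon, meta to a large group, cyano and isopropyl cannot be told apart in this assay: the step is a 1.1-fold higher number from compound 3 to compound 4 (0.03 log units; within the scatter). These two groups differ in what is counted for them, since cyano holds a nitrogen and one hydrogen-bond acceptor while isopropyl holds only carbon and no acceptor, so that difference alone does not separate the two numbers in this small set. Isopropyl also stands clearly apart from the other two compounds, with a 5.1-fold higher number from compound 2 to compound 4 (0.71 log units; beyond the scatter) and an 11-fold higher number from compound 1 to compound 4 (1.05 log units; beyond the scatter), which means that all three groups shown on this carbon give a higher number than hydrogen, with methoxy the closest to it.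

The compounds shown leave open whether any group on this carbon can match or improve on hydrogen, for instance a fluorine atom, an amine, a carboxylic acid or a longer chain, and whether the same groups would behave alike on other carbons of that ring. Nothing available here offers an explanation for the match between cyano and isopropyl or for the rise over hydrogen.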